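Clearance after swapping the amide aryl group

The source may report more compounds than this note shows. Statements on the series, on what has been measured and on what is new or still open speak of the compounds shown alone.

Measured in an ADME assay on the whole organism (strain Sprague-Dawley) for pharmacokinetics, with Rattus norvegicus as the target, read by LC-MS, using cassette dosing, at a dose of 0.5 mg/kg by the intravenous route; a lower number here means slower removal, a higher number faster removal of the compound:
- Compound 1 `COCC1=C[C@@](C)(c2cc(NC(=O)c3ccc(C#N)cn3)ccc2F)N=C(N)O1`: 12.9 mL/min/kg
- Compound 2 `C[C@@]1(c2cc(NC(=O)c3cnc(OCF)cn3)ccc2F)C=C(CF)OC(N)=N1`: 34.4 mL/min/kg
- Compound 3 `Cc1cc(C#N)cnc1C(=O)Nc1ccc(F)c([C@]2(C)C=C(CF)OC(N)=N2)c1`: 21.8 mL/min/kg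

Compound 3, at 21.8 mL/min/kg, lies within the usual scatter of both compound 1 and compound 2. The next molecule is compound 4 `C[C@@]1(c2cc(NC(=O)c3ncc(OCF)nc3N)ccc2F)C=C(CF)OC(N)=N1`, which has 3-amino-5-(fluoromethoxy)pyrazin-2-yl in place of 5-cyano-3-methylpyridin-2-yl on a carbonyl carbon.

Within the data shown here, one measured step bears on this change: a 1.6-fold lower number from compound 2 to compound 3 (0.20 log units; within the scatter). That step brought in 5-cyano-3-methylpyridin-2-yl in place of 5-(fluoromethoxy)pyrazin-2-yl, so the new change runs roughly the opposite way. Among the measured compounds shown here, the 3-amino part is new, and no measured compound shows what it does. For the measured compounds named here, with only that small step as a guide, no shift beyond the scatter is expected in this assay. The expected change is a 1.2-fold higher number from compound 3 to compound 4 (0.08 log units; within the scatter). For compound 4 the estimated clearance is 26 mL/min/kg, with an expected range of 13 mL/min/kg to 50 mL/min/kg.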

Compound 4, clearance: 45.3 mL/min/kg
Beside the measured number, compound 4's estimate is 1.7-fold (0.24 log units) below it; measured number inside the range.
By their numbers in this assay, from the lowest: compounds 1, 3, 2 and 4 (each within the scatter of the next, the first and the last beyond it).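

In this assay, among these compounds, replacing the whole amide aryl group gives a 2.1-fold higher number from compound 3 to compound 4 (0.32 log units; beyond the scatter), a modest shift and the first single-place step in this set to pass beyond the scatter. Amino in place of hydrogen on an aromatic carbon gives a 1.3-fold higher number from compound 2 to compound 4 (0.12 log units; within the scatter), which stays within the scatter, so the amino group alone cannot be shown to alter clearance. The shift beyond the scatter therefore appears only when 3-amino-5-(fluoromethoxy)pyrazin-2-yl is compared with 5-cyano-3-methylpyridin-2-yl, a change of the whole group rather than of one substituent.

Nothing available explains why clearance differs between these two groups. From the compounds shown here alone, it remains open whether a methylamino or hydroxyl group on that aromatic carbon would give a clearance like that of the amino group, and whether an amino group on the cyano-bearing pyridine group would behave as it does here.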